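Halogen swap on the anilide ring: lipophilicity notes

This account rests on a few compounds, and the source may have more. Where it says the series, first, only, none or still open, it means among the compounds named here.

Compound 1 `COc1cc2c(cc1OC)C(=O)C(C(=O)Nc1ccc(F)cc1)C2`, compound 2 `COc1cc2c(cc1OC)C(=O)C(C(=O)Nc1ccc(Br)cc1)C2` and compound 3 `COc1cc2c(cc1OC)C(=O)C(C(=O)Nc1ccccc1F)C2` share one core and differ only in the substituted phenyl ring on the amide-type nitrogen. In a physicochemical assay for lipophilicity, read by mass spectrometry (on this read-out higher numbers stand for higher lipophilicity and lower numbers for lower lipophilicity), compound 1 gives 2.36, compound 2 gives 3.03 and compound 3 gives 2.36. Compound 3 differs from compound 1 by 2-fluorophenyl in place of 4-fluorophenyl on an amide-type nitrogen, and this gives no change at the digits printed from compound 1 to compound 3 (within the scatter). Compound 2 differs from compound 1 by bromo in place of fluoro on an aromatic carbon, and this gives a number 0.67 log units higher from compound 1 to compound 2 (beyond the scatter).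

Compound 4 `COc1cc2c(cc1OC)C(=O)C(C(=O)Nc1ccccc1Br)C2` has not yet been measured in this assay. It differs from compound 3 by bromo in place of fluoro on an aromatic carbon. This is the same kind of change as from compound 1 to compound 2, but the place is not identical: in compound 2 the bromo sits para to a large group, in compound 4 ortho to a large group. The step from compound 3 to compound 4 is expected to be about a number 0.67 log units higher from compound 3 to compound 4 (beyond the scatter), resting on a number 0.67 log units higher from compound 1 to compound 2 (beyond the scatter) and on the finding that no change at the digits printed from compound 1 to compound 3 (within the scatter) shows no effect of moving the halogen. Compound 4 is therefore estimated at 3.03, with a range from 2.7 to 3.35.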

Compound 4, partition coefficient: 3.03
Estimate against measurement, compound 4: no gap at the digits printed; measured number inside the range.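

In this assay, bromo in place of fluoro on an aromatic carbon gives a number 0.67 log units higher from compound 3 to compound 4 (beyond the scatter) and, with the halogen in the other place, a number 0.67 log units higher from compound 1 to compound 2 (beyond the scatter) on the same shared core, so the change carries over between these two pairs at equal printed size. Moving the bromine, as 2-bromophenyl in place of 4-bromophenyl, gives no change at the digits printed from compound 2 to compound 4 (within the scatter) and the combined replacement gives a number 0.67 log units higher from compound 1 to compound 4 (beyond the scatter) in line with the two single changes. Both pairs share one core and one aromatic ring, so nothing here shows that the step would hold on a different core, and no measurement at hand explains the match.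

The compounds shown leave open whether a group other than a halogen, such as an amine or a carboxylic acid, would also read alike at both places on the phenyl ring. They also leave open where chloro would fall relative to fluoro and bromo.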